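A few compounds are considered here, and "the series" means these few. Any claim that something is new, unique, unknown or untested is made for them only; others in the source may bear on it.

Measured compounds:
- compound 1, `C/C(C#Cc1ccccc1)=N\N/C(N)=N/S(=O)(=O)c1cc(C)c(Cl)cc1SCc1cccc(C)c1`: 130000 nM
- compound 2, `C/C(C#Cc1ccccc1)=N\N/C(N)=N/S(=O)(=O)c1cc(C)c(Cl)cc1SCc1ccc(C)cc1`: 125000 nM
- compound 3, `C/C(C#Cc1ccccc1)=N\N/C(N)=N/S(=O)(=O)c1cc(C)c(Cl)cc1SCc1ccccc1Cl`: 114000 nM

All three compounds were tested in a functional assay on MCF7 cells (Homo sapiens) for antiproliferative activity, read by MTT assay, with a stated time of 72 h; on this read-out lower numbers stand for stronger inhibition and higher numbers for weaker inhibition. Compound 3 carries the lowest of the three numbers, yet the steps of a 1.1-fold lower number from compound 1 to compound 3 (0.06 log units; within the scatter) and a 1.1-fold lower number from compound 2 to compound 3 (0.04 log units; within the scatter) are both within the scatter, as is a 1.0-fold lower number from compound 1 to compound 2 (0.02 log units; within the scatter), so the three compounds cannot be told apart on these values.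

The next compound, compound 4, `C/C(C#Cc1ccccc1)=N\N/C(N)=N/S(=O)(=O)c1cc(C)c(Cl)cc1SCc1cccc(Cl)c1`, differs from compound 3 in one place: 3-chlorophenyl in place of 2-chlorophenyl on a saturated chain carbon bound to a sulfur. This is a change of the same kind as the measured steps, where only the group on the saturated chain carbon bound to a sulfur was varied, and every one of those steps stayed within the scatter. Nothing in the measured set points to a move in either direction in this assay, so the expected step is none beyond the scatter, and compound 4 is estimated to come out close to compound 3, as a 1.1-fold higher number from compound 3 to compound 4 (0.02 log units; within the scatter).

On that basis, compound 4 is expected to give 120000 nM in this assay, with a likely range from 80000 nM to 180000 nM.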

Compound 4, half-maximal inhibitory concentration: 80000 nM
Estimate against measurement, compound 4: 1.5-fold (0.18 log units) above, and the stated range covers the measured number.
By their numbers in this assay, from the lowest: compounds 4, 3, 2 and 1 (each within the scatter of the next).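

In this assay, the chlorine-bearing pair now gives a direct look at where the chlorine sits on the ring, and 3-chlorophenyl in place of 2-chlorophenyl on a saturated chain carbon bound to a sulfur gives a 1.4-fold lower number from compound 3 to compound 4 (0.15 log units; within the scatter). Within the data shown here, compound 4 also supplies the first clean swap of chloro for methyl on one aromatic carbon, with the rest of the molecule unchanged, and that swap gives a 1.6-fold lower number from compound 1 to compound 4 (0.21 log units; within the scatter), while replacing 4-methylphenyl with 3-chlorophenyl gives a 1.6-fold lower number from compound 2 to compound 4 (0.19 log units; within the scatter). These are the largest steps seen so far in this series, but all of them remain within the scatter, so the four compounds still cannot be told apart, and nothing available offers an explanation for the values.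

As far as these compounds go, all four compounds carry a substituted phenyl ring with a single chloro or methyl group at this place, so it remains open whether a very different group would produce a real change. A carboxylic acid, an amine or a longer chain on the saturated chain carbon bound to a sulfur could test this, as could a methoxy group on the phenyl ring.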